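The compounds below may be only part of what the source reports. "The series", "measured", "known", "first", "only" and "open" are said of these compounds alone.

The measured compounds:
Compound 1, `COc1ccc(C(O)(Cc2ccc(F)cc2)c2cccc3ccccc23)c(OC)c1OC`: 5940 nM
Compound 2, `COc1ccc(C(c2ccc(OCCO)cc2)c2cccc3ccccc23)c(OC)c1OC`: > 20000 nM
Compound 3, `CCOC(=O)C(C)C(O)(c1ccc(OC)c(OC)c1OC)c1cccc2ccccc12`: 4000 nM

These three were tested in a functional assay on A549 cells (Homo sapiens) for inhibition, read by sulforhodamine B assay, with a stated time of 48 h; a lower number here means a stronger inhibitor, a higher number a weaker inhibitor. Compound 2 stands at the limit of > 20000 nM in this assay, at which 1 of the 3 values shown sits; this is a limit of the assay and not a measured number. Within the data shown here, compound 1 and compound 3 both give measured numbers, and the one measured step between them, a 1.5-fold lower number from compound 1 to compound 3 (0.17 log units; within the scatter), changed nothing beyond the scatter.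

Compound 4, `COc1ccc(C(c2ccc(OCC(=O)O)cc2)c2cccc3ccccc23)c(OC)c1OC`, differs from compound 2 in a single place: carboxy in place of hydroxymethyl on a saturated chain carbon bound to an oxygen on an aromatic ring. Among the measured compounds shown here, no measured step touches this place; the only measured step concerns a different carbon, so it offers no direct guide to the change. With compound 2 known only as a limit, there is also no firm starting number. Compound 4 is therefore expected to give about 20000 nM, with a range from 7000 nM to 60000 nM, and quite possibly only a limit again. The step of a number no higher from compound 2 to compound 4 (the limit leaves the size open) is expected to stay within the scatter, with no clear direction.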

Compound 4, half-maximal inhibitory concentration: 16400 nM
Beside the measured number, compound 4's estimate is 1.2-fold (0.09 log units) above it, within the range that was stated.
By their numbers in this assay, from the lowest: compounds 3 and 1 (each within the scatter of the next); then compound 4. At a limit, above all of these: compound 2.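

At this position, on a saturated chain carbon bound to an oxygen on an aromatic ring, hydroxymethyl can give way to carboxy and the compound still returns a measured number in this assay, which gives this part of the series its first firm value. The change reads as an at least 1.2-fold lower number from compound 2 to compound 4 (0.08 log units; that floor lies within the scatter), so only a floor for the step is known and its true size cannot be read. That uncertainty sits with the starting compound, which has a limit of the assay and no measured number: the limit of > 20000 nM in this assay, at which 1 of the 4 values shown sits.

On these data alone, whether the change from hydroxymethyl to carboxy truly moves the number beyond the scatter stays open. Also open, as far as these compounds go, is how an amine, an amide or a longer chain ending in a carboxylic acid would read at this place on the shared core.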